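Dropping the Isopropylsulfanyl Group: What Cytotoxicity to Expect

This account rests on a few compounds, and the source may have more. Where it says the series, first, only, none or still open, it means among the compounds named here.

Compound 2 `CC1=CCC[C@H]2[C@](C)(CC3=CC(=O)C(SC(C)C)=CC3=O)[C@@H](C)CC[C@]12C` gives 86000 nM in a functional assay on Fem-X cells (Homo sapiens) for cytotoxicity; a higher number here means a weaker inhibitor, a lower number a stronger inhibitor. Among the three measured compounds it holds the second highest number; its nearest neighbour, compound 1 `CCCSC1=CC(=O)C(C[C@]2(C)[C@@H](C)CC[C@]3(C)C(C)=CCC[C@@H]23)=CC1=O`, gives 89500 nM, and its furthest, compound 3 `CC1=CCC[C@H]2[C@](C)(CC3=CC(=O)C4=C(SCCS4)C3=O)[C@@H](C)CC[C@]12C`, gives 75000 nM, both gaps lying within the scatter. Compound 4 `CC1=CCC[C@H]2[C@](C)(CC3=CC(=O)C=CC3=O)[C@@H](C)CC[C@]12C` differs from compound 2 in one place: hydrogen in place of isopropylsulfanyl on a double-bonded ring carbon. Within the data shown here, the only measured step at this spot is a 1.0-fold lower number from compound 1 to compound 2 (0.02 log units; within the scatter), within the scatter, yet it merely swaps one chain on the sulfur for another, whereas here the whole group leaves. That step gives limited guidance, and compound 3 shows a different sulfur-bearing group also giving a similar number. Compound 4 is therefore expected to stay close, a 1.1-fold lower number from compound 2 to compound 4 (0.03 log units; within the scatter). The estimate for compound 4 is 80000 nM, with a range from 30000 nM to 200000 nM.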

Compound 4, half-maximal inhibitory concentration: 23900 nM
Estimate against measurement, compound 4: 3.3-fold (0.52 log units) above; measured number outside the range, below it.
By their numbers in this assay, from the lowest: compound 4; then compounds 3, 2 and 1 (each within the scatter of the next).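

Swapping one chain on the sulfur for another left the number in this assay unchanged within the scatter, but removing the sulfur-bearing group altogether gives a 3.6-fold lower number from compound 2 to compound 4 (0.56 log units; beyond the scatter) and a 3.7-fold lower number from compound 1 to compound 4 (0.57 log units; beyond the scatter) on this double-bonded ring carbon. At this spot, then, plain hydrogen gives a stronger inhibitor than either isopropylsulfanyl or propylsulfanyl, so the presence of these groups matters more than the shape of their chain. Nothing available explains this difference.

As far as these compounds go, it remains open whether a group without sulfur, such as methoxy or an amine, would behave like hydrogen or like the sulfur-bearing groups here.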